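This account rests on a few compounds, and the source may have more. Where it says the series, first, only, none or still open, it means among the compounds named here.

Working notes on the series.

Compound 1, `CC1COC2(C)Oc3c(c4c(c5c3CC3C(C)COC3(C)O5)CC3C(C)COC3(C)O4)CC12`, gives 6000 nM in a functional assay on aorta (Rattus norvegicus, strain Sprague-Dawley) for inhibition; on this read-out higher numbers stand for an effect only at larger amounts of compound and lower numbers for an effect already at smaller amounts. Compound 2, `C[C@H]1CO[C@]2(C)Oc3c(c4c(c5c3C[C@@H]3[C@@H](C)CO[C@]3(C)O5)C[C@@H]3[C@@H](C)CO[C@]3(C)O4)C[C@H]12`, gives 12000 nM in this assay. Among the measured compounds shown here, the only step measured within the set is a 2.0-fold higher number from compound 1 to compound 2 (0.30 log units; within the scatter), and since the fact that one of compounds 1 and 2 is drawn with a defined configuration and the other without, at the place where they differ is the sole difference between the pair, that step says nothing about a change of substituent on the aromatic ring. Compound 3, `CCCCCCOc1cc2c(c3c1C[C@@H]1[C@@H](C)CO[C@]1(C)O3)C[C@@H]1[C@@H](C)CO[C@]1(C)O2`, is a different case: in this assay compound 3 reaches only the limit > 200000 nM, so no number stands for it, and the limit of > 200000 nM in this assay, at which 1 of the 3 values shown sits, is all that is known of its place among the three.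

Compound 4, `C[C@H]1CO[C@]2(C)Oc3cc(OC/C=C/c4ccccc4)c4c(c3C[C@H]12)O[C@@]1(C)OC[C@H](C)[C@H]1C4`, differs from compound 3 by 2-phenylethenyl in place of pentyl on a saturated chain carbon bound to an oxygen on an aromatic ring. For the measured compounds named here, no measured step in the set covers an exchange of this kind, so the expectation for compound 4 rests on the limit of compound 3 alone. Compound 4 is therefore estimated to stay weak in this assay, with a step of an at least 1.3-fold lower number from compound 3 to compound 4 (0.12 log units; that floor lies within the scatter) expected. The estimate for compound 4 is 150000 nM, ranging from 30000 nM to 400000 nM.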

Compound 4, half-maximal effective concentration: 64000 nM
Compound 4: the middle estimate sits 2.3-fold (0.37 log units) above what was measured; measured number inside the range.
By their numbers in this assay, from the lowest: compounds 1 and 2 (each within the scatter of the next); then compound 4. At a limit, above all of these: compound 3.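

Among the compounds shown here, with 2-phenylethenyl in place of pentyl on a saturated chain carbon bound to an oxygen on an aromatic ring, this assay gives an at least 3.1-fold lower number from compound 3 to compound 4 (0.49 log units; beyond the scatter), the first step in the set that lies beyond the scatter and the first that touches this position. The read-out therefore responds to the group at this position, which compound 3 alone, at its limit of > 200000 nM, could not show. The true size of the step remains unknown, and it is only a floor because one end of it is a limit: the limit of > 200000 nM in this assay, at which 1 of the 4 values shown sits.

The aromatic ring and the double bond enter together, so compounds 3 and 4 do not separate their contributions. Going by these compounds, how an amine or a carboxylic acid in place of 2-phenylethenyl at this position would read in this assay also stays open.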